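Swapping a Thiophene Amide for a Dichlorophenyl Amide

This account rests on a few compounds, and the source may have more. Where it says the series, first, only, none or still open, it means among the compounds named here.

Compound 1 `COc1cc(/C=C/C(=O)c2cccc(N)c2)ccc1O` carries a free amine on an aromatic ring of the shared core. In a functional assay on B16 cells (Mus musculus) for inhibition (on this read-out higher numbers stand for weaker inhibition and lower numbers for stronger inhibition), compound 1 gives 11.5 ug/mL. Compound 2 `COc1cc(/C=C/C(=O)c2cccc(NC(=O)C(C)C)c2)ccc1O` caps that nitrogen with an isopropylcarbonyl group, and in this assay compound 2 gives 1.09 ug/mL; the step reads an 11-fold lower number from compound 1 to compound 2 (1.02 log units; beyond the scatter). Compound 3 `COc1cc(/C=C/C(=O)c2cccc(NC(=O)c3cccs3)c2)ccc1O` carries a (thiophen-2-yl)carbonyl group on the same nitrogen, and in this assay compound 3 gives 6.93 ug/mL. Among the three measured numbers, compound 3 stands second highest: from the free amine the step is a 1.7-fold lower number from compound 1 to compound 3 (0.22 log units; within the scatter), while against the isopropyl amide the step is a 6.4-fold higher number from compound 2 to compound 3 (0.80 log units; beyond the scatter).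

Compound 4 `COc1cc(/C=C/C(=O)c2cccc(NC(=O)c3ccc(Cl)cc3Cl)c2)ccc1O` differs from compound 3 in one place: 2,4-dichlorophenyl in place of thiophen-2-yl on a carbonyl carbon. The step that bears most directly on this change is a 6.4-fold higher number from compound 2 to compound 3 (0.80 log units; beyond the scatter), where an aromatic ring on the carbonyl carbon gave a higher number than an alkyl group; the step of a 1.7-fold lower number from compound 1 to compound 3 (0.22 log units; within the scatter) shows that this aromatic amide barely moved the number away from the free amine. Compound 4 also carries an aromatic ring on the carbonyl carbon, and resting on a 6.4-fold higher number from compound 2 to compound 3 (0.80 log units; beyond the scatter) the expected step for compound 4 is a 1.3-fold lower number from compound 3 to compound 4 (0.10 log units; within the scatter), with no direction beyond the scatter. Compound 4 is therefore estimated at 5.5 ug/mL in this assay, with a range from 1.8 ug/mL to 16 ug/mL.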

Compound 4, half-maximal inhibitory concentration: 12.8 ug/mL
Estimate against measurement, compound 4: 2.3-fold (0.37 log units) below; low and high end bracket the measured number.
By their numbers in this assay, from the lowest: compound 2; then compounds 3, 1 and 4 (each within the scatter of the next).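

In this assay, replacing thiophen-2-yl with 2,4-dichlorophenyl on the carbonyl carbon produces no readable change, with a 1.8-fold higher number from compound 3 to compound 4 (0.27 log units; within the scatter). The new amide also stays level with the free amine, with a 1.1-fold higher number from compound 1 to compound 4 (0.05 log units; within the scatter), so neither of the two aromatic groups shown on this carbonyl carbon separates its compound from the uncapped nitrogen. The isopropyl amide alone stands apart, with a 12-fold higher number from compound 2 to compound 4 (1.07 log units; beyond the scatter), which shows that capping the nitrogen does not by itself lower the number and that the result depends on the group attached to the carbonyl carbon.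

Nothing measured here explains why the isopropyl amide differs from the two aromatic amides. On these data alone, it also remains open whether this advantage belongs to isopropyl alone or extends to other alkyl groups such as cyclopropyl, tert-butyl or a longer chain like n-butyl, and whether a plain phenyl without its two chlorines would stay level with compound 3 and compound 4.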